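The source may report more compounds than this note shows. Statements on the series, on what has been measured and on what is new or still open speak of the compounds shown alone.

Measured so far in an ADME assay on liver (Homo sapiens) for metabolic stability, using microsomes; on this read-out higher numbers stand for a longer-lived compound and lower numbers for a shorter-lived compound:
- Compound 1 `CN1Cc2cc(ccc2S(=O)(=O)C2CC2)NC(=O)CCc2cc(ccc2OCC2CC2)[C@@H](Nc2ccc3c(N)ncc(F)c3c2)C1=O`: 0.383 h
- Compound 2 `CN1CCc2cccc(c2)[C@@H](Nc2ccc3c(N)ncc(F)c3c2)C(=O)N(C)Cc2cc(ccc2S(=O)(=O)C2CC2)NC1=O`: 0.0833 h
- Compound 3 `COc1ccc2cc1[C@@H](C)CN(C)C(=O)Nc1ccc(S(=O)(=O)C3CC3)c(c1)CN(C)C(=O)[C@@H]2Nc1ccc2c(N)ncc(F)c2c1`: 0.0667 h

Compound 1 stands highest of the three, and its gaps to compound 2 and to compound 3 both lie beyond the usual scatter of repeated measurements. No two of these compounds differ in only one place, so none of the gaps isolates the effect of a single change.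

The next compound to be measured is compound 4 `CN1Cc2cc(ccc2S(=O)(=O)C2CC2)NC(=O)CCc2cc(ccc2OCC(F)F)[C@@H](Nc2ccc3c(N)ncc(F)c3c2)C1=O`, which differs from compound 1 in one place: difluoromethyl in place of cyclopropyl on a saturated chain carbon bound to an oxygen on an aromatic ring. The same difference can be read as cyclopropylmethoxy to 2,2-difluoroethoxy. Going by the values given here, no measured pair shows this change, so the expectation is loose: a small rise in this assay that stays within the scatter, taking compound 1 at 0.383 h as the starting point. The expected change is a 1.6-fold higher number from compound 1 to compound 4 (0.19 log units; within the scatter). Compound 4 is estimated at 0.6 h, with an expected range of 0.25 h to 1.4 h.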

Compound 4, half-life: 0.533 h
The estimate for compound 4 lay 1.1-fold (0.05 log units) above the measured number; measured number inside the range.
By their numbers in this assay, from the lowest: compounds 3 and 2 (each within the scatter of the next); then compounds 1 and 4 (each within the scatter of the next).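

In this assay, putting difluoromethyl in place of cyclopropyl on a saturated chain carbon bound to an oxygen on an aromatic ring gives a 1.4-fold higher number from compound 1 to compound 4 (0.14 log units; within the scatter). Going by these compounds alone, this is the first pair here that differs in one place, and it shows that this particular swap, which removes the ring while keeping the same count of heavy atoms, leaves the half-life within the scatter of the parent compound. Nothing available here explains this result.

As far as these compounds go, whether a trifluoromethyl group, an amine or a longer chain at the same place would shift the half-life beyond the scatter remains open. A single pair also cannot show whether the same swap would read the same way on a different core.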